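Restoring an Aromatic Chain End to Compound 3

This account rests on a few compounds, and the source may have more. Where it says the series, first, only, none or still open, it means among the compounds named here.

In a functional assay on HOS-TE85 cells (Homo sapiens) for inhibition, read by CCK-8 assay, with a stated time of 72 h (a lower number here means a stronger inhibitor, a higher number a weaker inhibitor), compound 3 `COc1ccccc1N1C(=O)CSC1c1cccc(C(=O)NCCCCN2C(=O)C=CC2=O)c1` gives > 1000 nM as its reading, which is a limit of the assay and not a number. Compound 1 `COc1ccccc1N1C(=O)CSC1c1cccc(C(=O)NCCCCc2ccc(Cl)cc2)c1` gives 78.6 nM as a measured value. Compound 2 `COc1ccccc1N1C(=O)CSC1c1cccc(C(=O)NCCCCn2cccn2)c1` gives 91.7 nM as a measured value. Exchanging one aromatic end group for another in these two made little difference, with a 1.2-fold higher number from compound 1 to compound 2 (0.07 log units; within the scatter) as the result.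

Compound 4 `COc1ccccc1N1C(=O)CSC1c1cccc(C(=O)NCCCCn2ccc3ccccc32)c1` differs from compound 3 by one change: a group of 9 heavy atoms (8 carbon, 1 nitrogen; one five-membered aromatic ring with 1 hetero atom, one six-membered aromatic ring of carbon only) in place of a group of 7 heavy atoms (4 carbon, 1 nitrogen, 2 oxygen; one five-membered non-aromatic ring with 1 hetero atom), on a saturated chain carbon, four bonds along the chain from an amide-type nitrogen is the full count. The new 1H-indol-1-yl group is aromatic, like the end groups of compound 1 and compound 2. Two large measured steps bear on this, an at least 12-fold higher number from compound 1 to compound 3 (1.10 log units; beyond the scatter) and an at least 10-fold higher number from compound 2 to compound 3 (1.03 log units; beyond the scatter) both being beyond the scatter. Reversing that kind of exchange should therefore bring a large drop, and the expected change is an at least 8.3-fold lower number from compound 3 to compound 4 (0.92 log units; beyond the scatter) as estimated here. Compound 4 is estimated to give 120 nM with 30 nM to 500 nM as the expected range.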

Compound 4, half-maximal inhibitory concentration: 286 nM
Estimate against measurement, compound 4: 2.4-fold (0.38 log units) below, within the range that was stated.
By their numbers in this assay, from the lowest: compounds 1 and 2 (each within the scatter of the next); then compound 4. At a limit, above all of these: compound 3.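

In this assay the change to 1H-indol-1-yl gives an at least 3.4-fold lower number from compound 3 to compound 4 (0.54 log units; beyond the scatter) and so brings back measurable inhibition, but compound 4 does not rejoin the two earlier aromatic compounds. Until now, exchanging one aromatic end group for another at this chain end had changed little, yet here there is a 3.1-fold higher number from compound 2 to compound 4 (0.49 log units; beyond the scatter) and also a 3.6-fold higher number from compound 1 to compound 4 (0.56 log units; beyond the scatter) so an aromatic end group alone does not fix the level, and compound 4 is the one that goes against that simple reading. The first of these steps gives only a minimum size, because compound 3 is held at a limit of the assay: the limit of > 1000 nM in this assay, at which 1 of the 4 values shown sits.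

Where an amine or a carboxylic acid at this chain end would fall remains open. So does whether unsubstituted phenyl or a longer chain would keep the level of compound 1.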